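Sulfonamide aryl swap: difluorophenyl to dimethylaminophenyl

This account rests on a few compounds, and the source may have more. Where it says the series, first, only, none or still open, it means among the compounds named here.

The series shares one core, carried by compound 1 `CC(C)CN(c1ccc(C#N)cc1)S(=O)(=O)c1ccc2c(c1)C(=O)CC(C1CCOCC1)O2` and compound 2 `CC(C)CN(c1ccc(F)cc1F)S(=O)(=O)c1ccc2c(c1)C(=O)CC(C1CCOCC1)O2`, which differ only in the aryl group on the sulfonamide nitrogen. In a physicochemical assay for lipophilicity, at pH 7.4 (on this read-out higher numbers stand for higher lipophilicity and lower numbers for lower lipophilicity), compound 1 gives 3.16, and compound 2 gives 3.62, the higher of the two numbers, with the step of a number 0.46 log units higher from compound 1 to compound 2 (beyond the scatter). Compound 3 `CC(C)CN(c1ccc(N(C)C)cc1)S(=O)(=O)c1ccc2c(c1)C(=O)CC(C1CCOCC1)O2` is the next member, not yet measured, and it differs from compound 2 as follows: 4-(dimethylamino)phenyl in place of 2,4-difluorophenyl on a sulfonamide nitrogen. Within the data shown here, only the step from compound 1 to compound 2 offers any guidance, and it concerns a different pair of aryl groups, so it informs the expected size of a swap on this nitrogen more than its direction. On that basis, compound 3 is expected to land close to compound 2 in this assay, with a change of about a number 0.12 log units lower from compound 2 to compound 3 (within the scatter) that need not exceed the usual scatter. The estimate for compound 3 is 3.5, with a likely range from 3.1 to 3.9.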

Compound 3, distribution coefficient: 3.6
Beside the measured number, compound 3's estimate is 0.10 log units below it; low and high end bracket the measured number.
By their numbers in this assay, from the lowest: compound 1; then compounds 3 and 2 (each within the scatter of the next).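

In this assay, putting 4-(dimethylamino)phenyl in place of 2,4-difluorophenyl on the sulfonamide nitrogen gives a number 0.02 log units lower from compound 2 to compound 3 (within the scatter), so this read-out does not separate the two groups, even though the entering group brings a nitrogen and a hydrogen-bond acceptor that the leaving group lacks. The change of cyano to dimethylamino on an aromatic carbon gives a number 0.44 log units higher from compound 1 to compound 3 (beyond the scatter), which matches the earlier picture of a number 0.46 log units higher from compound 1 to compound 2 (beyond the scatter): among these three compounds, compound 1 with its 4-cyanophenyl stands apart, while compounds 2 and 3 stay together. Nothing in the available evidence accounts for either the agreement between compounds 2 and 3 or the separate place of compound 1.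

The compounds shown leave open whether other aryl groups on this nitrogen, such as an unsubstituted phenyl or a phenyl carrying a methoxy group or a carboxylic acid, would fall with compounds 2 and 3 or with compound 1. They also leave open whether a primary amine in place of the dimethylamino group would behave like the dimethylamino group or like the cyano group.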